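Notes on replacing the 2,6-dimethoxyphenyl group of compound 2

A few compounds are considered here, and "the series" means these few. Any claim that something is new, unique, unknown or untested is made for them only; others in the source may bear on it.

- compound 1 `O=C(Cc1csc2nc(-c3ccc(Br)cc3)cn12)N/N=C/c1ccccc1O`: 2090 nM
- compound 2 `COc1cccc(OC)c1/C=N/NC(=O)Cc1csc2nc(-c3ccc(Br)cc3)cn12`: 12000 nM

In a functional assay on UACC-62 cells (Homo sapiens) for inhibition, read by sulforhodamine B assay, with a stated time of 48 h (on this read-out higher numbers stand for weaker inhibition of growth and lower numbers for stronger inhibition of growth), compound 2 has the higher of the two numbers, so it is the weaker growth inhibitor of the pair. Compound 3 `O=C(Cc1csc2nc(-c3ccc(Br)cc3)cn12)N/N=C/c1ccc(Cl)cc1Cl` keeps the shared core and has 2,4-dichlorophenyl in place of 2,6-dimethoxyphenyl on a carbon with a double bond to nitrogen. Among the measured compounds shown here, one measured step bears on this place: a 5.7-fold higher number from compound 1 to compound 2 (0.76 log units; beyond the scatter), modest and beyond the scatter. For the measured compounds named here, that step introduced the group now leaving, but no measured compound carries 2,4-dichlorophenyl, so the direction remains uncertain. A modest move towards a lower number in this assay is expected, smaller than or close to that measured step. The estimate is a 2.4-fold lower number from compound 2 to compound 3 (0.38 log units; beyond the scatter). Compound 3 is expected at 5000 nM, with an estimated range of 1600 nM to 15000 nM.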

Compound 3, concentration for 50% growth inhibition: 23400 nM
The estimate for compound 3 lay 4.7-fold (0.67 log units) below the measured number; the whole stated range lies below it.
By their numbers in this assay, from the lowest: compound 1; then compounds 2 and 3 (each within the scatter of the next).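

In this assay, the two groups at this position on the carbon with a double bond to nitrogen are not separated, as 2,4-dichlorophenyl in place of 2,6-dimethoxyphenyl gives only a step within the scatter (a 2.0-fold higher number from compound 2 to compound 3 (0.29 log units; within the scatter)). The 2-hydroxyphenyl group of compound 1 now stands apart from both other groups, and its replacement by 2,4-dichlorophenyl gives the largest step in the set (an 11-fold higher number from compound 1 to compound 3 (1.05 log units; beyond the scatter)), making compound 1 the strongest growth inhibitor of the three. Nothing available explains this difference.

Still open, on these data alone, is whether the hydroxyl group of compound 1 is itself what sets it apart from compound 2 and compound 3. An unsubstituted phenyl group, or a phenyl ring carrying an amine or a carboxylic acid, would help to test this.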